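Aziridine carbonitrile ureas: acetyl removal on the aromatic ring

The source may report more compounds than this note shows. Statements on the series, on what has been measured and on what is new or still open speak of the compounds shown alone.

Measured so far:
- compound 1, `CC(=O)c1cccc(NC(=O)N2CC2C#N)c1`: 9000 nM
- compound 2, `N#CC1CN1C(=O)Nc1cccnc1`: 18000 nM
- compound 3, `CNC(=O)N1CC1C#N`: 23000 nM

All three share the aziridine carbonitrile urea core and were tested in a functional assay on WiDr cells (Homo sapiens) for inhibition; a higher number here means a weaker inhibitor, a lower number a stronger inhibitor. Compound 1 sits at the low end of the three numbers. Its gap to compound 2 lies within the usual scatter of repeated runs, so no order between compound 1 and compound 2 can be read from these two values. Its gap to compound 3 lies beyond the scatter, so compound 3 does give a higher number than compound 1. No pair of these compounds differs in a single place, so no single-change step can be read off from the measured set.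

The next compound, compound 4, `N#CC1CN1C(=O)Nc1ccccc1`, differs from compound 1 in one place: hydrogen in place of acetyl on an aromatic carbon. The urea and the six-membered aromatic ring of carbon only are kept. With no measured step of this kind in the series, the expectation rests on the closeness of compound 1 and compound 2, both of which carry an aromatic ring on the urea nitrogen and lie within the scatter of each other. A step from compound 1 to compound 4 that stays near the scatter, or only a little beyond it toward a higher number, is expected: a 1.4-fold higher number from compound 1 to compound 4 (0.16 log units; within the scatter). For compound 4 in this assay the estimate is 13000 nM, with a range from 5000 nM to 32000 nM.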

Compound 4, half-maximal inhibitory concentration: 12000 nM
The estimate for compound 4 lay 1.1-fold (0.03 log units) above the measured number; measured number inside the range.
By their numbers in this assay, from the lowest: compounds 1, 4, 2 and 3 (each within the scatter of the next, the first and the last beyond it).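

In this assay, within the data shown here, hydrogen in place of acetyl on an aromatic carbon, meta to a group of 8 heavy atoms, gives a 1.3-fold higher number from compound 1 to compound 4 (0.12 log units; within the scatter), the first step that can be read as a change in one place. At this position on the six-membered aromatic ring of carbon only, the acetyl, with its 3 heavy atoms, its double bond outside aromatic rings and its 1 hydrogen-bond acceptor, can therefore be exchanged for hydrogen without the step leaving the scatter, so this pair gives no sign that the number depends on the acetyl. No measurement shown bears on the reason for this outcome.

On these data alone, a single exchange at a single position says nothing yet about other groups there, so it remains open whether an amine, a carboxylic acid or a longer chain at this aromatic carbon would give a step beyond the scatter. Also open, as far as these compounds go, is whether acetyl at another carbon of the ring would give a similarly small step, and how much of the numbers depends on the shared core.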